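Replacing 3-oxomorpholin-4-yl with (2-hydroxyethyl)sulfonyl

This account rests on a few compounds, and the source may have more. Where it says the series, first, only, none or still open, it means among the compounds named here.

Two compounds in the series have numbers in a physicochemical assay for lipophilicity, measured as octanol-water partition, at pH 7.4; a lower number here means a more polar compound, a higher number a more lipophilic compound: compound 1 `CC(C)c1noc(N2CCC(Oc3cc(N4CCc5cc(N6CCCS6(=O)=O)ccc54)ncn3)CC2)n1` gives 3.2 and compound 2 `CC(C)c1noc(N2CCC(Oc3cc(N4CCc5cc(N6CCOCC6=O)ccc54)ncn3)CC2)n1` gives 3.1. These two values lie within the scatter of each other, so compound 2 has no separate standing on this short scale. Compound 3 `CC(C)c1noc(N2CCC(Oc3cc(N4CCc5cc(S(=O)(=O)CCO)ccc54)ncn3)CC2)n1` carries (2-hydroxyethyl)sulfonyl in place of 3-oxomorpholin-4-yl on an aromatic carbon. Going by the values given here, only one measured step bears on this change, a number 0.10 log units lower from compound 1 to compound 2 (within the scatter), and it exchanged one ring-bearing group for another. Among the compounds with values here, the group entering here has no ring, so that step is a weak guide and no measured step covers an open chain. A modest move to a lower number is expected, a number 0.30 log units lower from compound 2 to compound 3 (within the scatter), with limited support from the data. For compound 3 the estimated value is 2.8, with an expected range of 2.3 to 3.2.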

Compound 3, distribution coefficient: 2.7
Beside the measured number, compound 3's estimate is 0.10 log units above it, and the stated range covers the measured number.
By their numbers in this assay, from the lowest: compound 3; then compounds 2 and 1 (each within the scatter of the next).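

On an aromatic carbon of this position, the exchange of one ring-bearing group for another gave only a number 0.10 log units lower from compound 1 to compound 2 (within the scatter) in this assay, whereas the open-chain (2-hydroxyethyl)sulfonyl gives the first shifts beyond the scatter: a number 0.40 log units lower from compound 2 to compound 3 (beyond the scatter) and a number 0.50 log units lower from compound 1 to compound 3 (beyond the scatter). The position therefore does respond in this read-out, and compound 3 stands apart from compounds 1 and 2, which remain within the scatter of each other. No supporting evidence is available to explain this shift.

The change removes the ring and adds a hydrogen-bond donor in one step, so the compounds shown do not separate these two differences. Comparison with methylsulfonyl, which lacks the hydroxyl, or with a longer hydroxyalkylsulfonyl chain at the same carbon would help to assign the shift to one part of the group.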